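Anilinomethyl thione series: from chlorophenyl to methylphenyl

The source may hold more compounds than are shown below. What is called first, only, known or untested is meant among the compounds shown, and "the series" means these compounds.

Measured compounds:
- compound 1, `CCCCCCCCCCCCCCCCNCn1nc(-c2ccc3c(c2)OCCO3)oc1=S`, in a functional assay, with a stated time of 6 min (on this read-out lower numbers stand for stronger inhibition and higher numbers for weaker inhibition), compound 1 gives 22900 nM
- compound 2, `FC(F)(F)c1cccc(NCn2nc(-c3ccc4c(c3)OCCO4)oc2=S)c1`, in this assay compound 2 gives 7620 nM
- compound 3, `S=c1oc(-c2ccc3c(c2)OCCO3)nn1CNc1cccc(Cl)c1`, in this assay compound 3 gives 6220 nM

Compound 3 sits at the low end of these three numbers. Against compound 2 the difference is a 1.2-fold lower number from compound 2 to compound 3 (0.09 log units; within the scatter), so the two cannot be told apart. Against compound 1 the gap lies beyond the scatter, compound 1 giving the higher number.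

The next compound, compound 4, `Cc1ccc(NCn2nc(-c3ccc4c(c3)OCCO4)oc2=S)cc1`, differs from compound 3 by 4-methylphenyl in place of 3-chlorophenyl on an amine nitrogen. Among the measured compounds shown here, no measured step covers this exact change. For the measured compounds named here, the only step that touches the same region, from trifluoromethyl to chloro on the aromatic ring, was within the scatter, which suggests that swapping one small aryl substituent for another has so far made little difference here. On that basis the step is expected to be a 1.1-fold higher number from compound 3 to compound 4 (0.05 log units; within the scatter), with no clear direction. Compound 4 is therefore estimated at 7000 nM, with a likely range from 3000 nM to 16000 nM.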

Compound 4, half-maximal inhibitory concentration: 5700 nM
Beside the measured number, compound 4's estimate is 1.2-fold (0.09 log units) above it, and the stated range covers the measured number.
By their numbers in this assay, from the lowest: compounds 4, 3 and 2 (each within the scatter of the next); then compound 1.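

In this assay the swap gives a 1.1-fold lower number from compound 3 to compound 4 (0.04 log units; within the scatter), so compound 3 and compound 4 cannot be told apart. The earlier step, from trifluoromethyl to chloro, kept the aryl group otherwise alike, whereas this one replaces 3-chlorophenyl on the amine nitrogen with 4-methylphenyl, altering both the substituent and the number in the group's name, and still leaves the read-out within the scatter. Nothing available here explains this result or says anything further about the two aryl groups.

Going by these compounds, what a carboxylic acid, an amine or a methoxy group on this aromatic ring would do remains open, as does the result for an unsubstituted phenyl on the amine nitrogen. On these data alone, the effect of any alteration to the shared core also stays open, since all four compounds carry it.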